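From acetyl to (tert-butyl)carbonyl on a shared core

The source may report more compounds than this note shows. Statements on the series, on what has been measured and on what is new or still open speak of the compounds shown alone.

Measured so far in a functional assay on BeWo cells (Homo sapiens) for inhibition, read by MTT assay, with a stated time of 72 h; on this read-out lower numbers stand for stronger inhibition and higher numbers for weaker inhibition:
- compound 1 `CC(=O)N1CCN(c2nnc3nncn3n2)CC1` gives 13100 nM
- compound 2 `c1nnc2nnc(N3CCCCC3)nn12` gives 10800 nM

Compound 1 stands within the usual scatter of compound 2, so these two numbers cannot be ranked. Compound 3 `CC(C)(C)C(=O)N1CCN(c2nnc3nncn3n2)CC1` keeps the core of compound 1 and changes one group: tert-butyl in place of methyl on a carbonyl carbon. In words, tert-butyl takes the place of methyl on a carbonyl carbon. Going by the values given here, no measured pair shows this change directly. Among the compounds with values here, the only guide is that compound 1 at 13100 nM and compound 2 at 10800 nM carry different groups on the shared core, yet their values sit within the scatter. In this assay, the expected result is therefore a small move towards a lower number, not beyond the scatter, estimated as a 1.4-fold lower number from compound 1 to compound 3 (0.14 log units; within the scatter). For compound 3 the estimated value is 9500 nM, with an expected range from 3500 nM to 22000 nM.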

Compound 3, half-maximal inhibitory concentration: 2410 nM
The estimate for compound 3 lay 3.9-fold (0.60 log units) above the measured number; measured number outside the range, below it.
By their numbers in this assay, from the lowest: compound 3; then compounds 2 and 1 (each within the scatter of the next).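

In this assay, tert-butyl in place of methyl on a carbonyl carbon gives a 5.4-fold lower number from compound 1 to compound 3 (0.74 log units; beyond the scatter). This is the first pair shown that differs in one place, and it reveals that the number responds to the group carried on this carbonyl carbon, which the earlier two compounds could not show. Nothing shown here explains why the number falls with this change.

Going by these compounds, with only methyl and tert-butyl compared at this place, it remains open whether an ethyl group, a longer unbranched chain such as n-butyl, a cyclohexyl ring or an amine on the same carbonyl carbon would give a number like that of compound 1 or compound 3. On these data alone, whether the same change would have a similar effect on a different core also remains open.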